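The compounds below may be only part of what the source reports. "The series", "measured", "known", "first", "only" and "open" are said of these compounds alone.

Measured compounds:
- compound 1 `CC1=C(C(=O)OCC(C)C)C(c2ccco2)NC(=S)N1`, in an assay on membranes from HEK293 cells for displacement of a labelled ligand from adenosine receptor A2b (Homo sapiens), read by scintillation counting, with a stated time of 30 min, tested at 1 uM (a higher number here means more inhibition at the concentration tested (going by the name of the read-out), a lower number less inhibition), compound 1 gives 18%
- compound 2 `CC1=C(C(=O)OCC(C)C)C(c2ccoc2)NC(=S)N1`, in this assay compound 2 gives 1%
- compound 3 `CCCOC(=O)C1=C(C)NC(=S)NC1c1ccsc1`, in this assay compound 3 gives 26%

Among the measured compounds shown here, compound 3 holds the highest of the three numbers, but its gap to compound 1 lies within the scatter, so the two cannot be ranked; only compound 2 stands clearly apart, and the step of a number 17 percentage points lower from compound 1 to compound 2 (beyond the scatter) shows that furan-3-yl in place of furan-2-yl on a saturated ring carbon is the one change that moved the read-out beyond the scatter.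

Compound 4 `CC1=C(C(=O)OCC(C)C)C(c2ccsc2)NC(=S)N1` differs from compound 3 by methyl in place of hydrogen on a saturated chain carbon bound to two saturated chain carbons. For the measured compounds named here, no measured pair touches this part of the molecule: compounds 1 and 2 already carry isobutoxy, and no propoxy counterpart of either exists among the measured compounds, so nothing bears directly on the step. Going by the values given here, the one step recorded, from compound 1 to compound 2, concerns a different position and is no guide here. In this assay the step of a number 2 percentage points lower from compound 3 to compound 4 (within the scatter) is therefore expected to stay within the scatter. For compound 4 the read-out is estimated at 24%, within 8% to 40%.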

Compound 4, a percentage reported as inhibition, at one concentration (the size of the read-out at that concentration, not a potency): 15%
Beside the measured number, compound 4's estimate is 9 percentage points above it; the measured number falls inside the stated range.
By their numbers in this assay, from the lowest: compound 2; then compounds 4, 1 and 3 (each within the scatter of the next, the first and the last beyond it).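

In this assay, among the compounds shown here, the change from propoxy to isobutoxy gives the first reading at this chain position, and it is not silent with thiophen-3-yl on the saturated ring carbon (a number 11 percentage points lower from compound 3 to compound 4 (beyond the scatter)). With isobutoxy held fixed, the ring group can now be compared across three compounds: thiophen-3-yl reads clearly apart from furan-3-yl (a number 14 percentage points higher from compound 2 to compound 4 (beyond the scatter)) but cannot be separated from furan-2-yl (a number 3 percentage points lower from compound 1 to compound 4 (within the scatter)), which leaves furan-3-yl alone at the low end of this trio. No evidence is available to explain either result.

Going by these compounds, whether the step from propoxy to isobutoxy carries over to the furan-2-yl or furan-3-yl compounds remains open. Also open, on these data alone, is how a longer chain such as pentyloxy at the ester, or a phenyl on the saturated ring carbon, would read.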